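Weak Antiproliferative Readings and a Dichlorophenyl Swap

The compounds below may be only part of what the source reports. "The series", "measured", "known", "first", "only" and "open" are said of these compounds alone.

- Compound 1 `O=C(O)CC(NS(=O)(=O)c1ccccc1)c1ccccc1`: > 100000 nM (a limit of the assay, not a number)
- Compound 2 `CC(C)(C)c1ccc(C(CC(=O)O)NS(=O)(=O)c2ccc(C(F)(F)F)cc2)cc1`: 53700 nM
- Compound 3 `O=C(O)CC(NC(=O)c1ccc(Cl)cc1Cl)c1ccccc1F`: 89300 nM

These compounds were tested in a functional assay on MDA-MB-231 cells (Homo sapiens) for antiproliferative activity, read by MTT assay, with a stated time of 24 h; a lower number here means a stronger inhibitor, a higher number a weaker inhibitor. Compound 3 at 89300 nM has one numerical neighbour, compound 2 at 53700 nM, and these two values lie within the usual scatter of each other. Neither can therefore be ranked over the other, and both numbers mean weak inhibition.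

The unmeasured compound 4 `O=C(O)CC(NC(=O)c1ccc(Cl)cc1Cl)c1ccc(Cl)cc1Cl` has 2,4-dichlorophenyl in place of 2-fluorophenyl on a saturated chain carbon bound to an amide-type nitrogen and a saturated chain carbon. Within the data shown here, no measured pair shows a change of this kind, so the expectation starts from compound 3 at 89300 nM. No change beyond the scatter is expected in this assay. The estimated step is a 1.4-fold lower number from compound 3 to compound 4 (0.14 log units; within the scatter). For compound 4 the estimated value is 65000 nM, with an expected range of 30000 nM to 100000 nM.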

Compound 4, half-maximal inhibitory concentration: 49200 nM
Estimate against measurement, compound 4: 1.3-fold (0.12 log units) above; the measured number falls inside the stated range.
By their numbers in this assay, from the lowest: compounds 4, 2 and 3 (each within the scatter of the next). At a limit, above all of these: compound 1.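

Among these compounds, compounds 3 and 4 form the first pair that differs in one place only, giving a direct reading of a change on the saturated chain carbon bound to an amide-type nitrogen and a saturated chain carbon. In this assay, putting 2,4-dichlorophenyl in place of 2-fluorophenyl there gives a step that cannot be told from ordinary assay noise (a 1.8-fold lower number from compound 3 to compound 4 (0.26 log units; within the scatter)), and both compounds remain weak inhibitors. Compound 1 stands apart, as its reading is a limit of the assay and not a number: the limit of > 100000 nM in this assay, at which 1 of the 4 values shown sits.

Both groups compared here are substituted phenyl rings, so the compounds shown leave open what an amine or a longer alkyl chain at this position would do in this assay. Also open, on these data alone, is whether any change at this position can move the number beyond the scatter.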